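Compound 1 to compound 4: adding pyridin-2-yl

The source may hold more compounds than are shown below. What is called first, only, known or untested is meant among the compounds shown, and "the series" means these compounds.

In a functional assay on MCF7 cells (Homo sapiens) for antiproliferative activity, read by MTT assay (on this read-out lower numbers stand for stronger inhibition and higher numbers for weaker inhibition), compound 1 `c1ccc2c(c1)ccn2-c1nc(N2CCNCC2)nc2ccccc12` gives 14.1 ug/mL, the lowest of the three numbers measured. Compound 2 `c1ccc2c(c1)ccn2-c1nc(N2CCCCC2)nc2ccccc12` gives 50 ug/mL, and compound 3 `Cn1cc(-c2nc(N3CCNCC3)nc3ccccc23)c2ccccc21` gives 50 ug/mL. Compound 4 `c1ccc(N2CCN(c3nc(-n4ccc5ccccc54)c4ccccc4n3)CC2)nc1`, not yet measured, carries pyridin-2-yl in place of hydrogen on an amine nitrogen in a ring. Going by the values given here, the one measured step that touches this ring is a 3.5-fold higher number from compound 1 to compound 2 (0.55 log units; beyond the scatter), a modest change beyond the scatter, with piperidin-1-yl in place of piperazin-1-yl. Among the compounds with values here, no measured compound carries a group on that nitrogen, so this guide is loose, and a rise of similar or smaller size is expected. The expected change is a 1.6-fold higher number from compound 1 to compound 4 (0.19 log units; within the scatter). Compound 4 is estimated at 22 ug/mL, with an expected range of 7 ug/mL to 60 ug/mL.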

Compound 4, half-maximal inhibitory concentration: 50 ug/mL
The estimate for compound 4 lay 2.3-fold (0.36 log units) below the measured number; measured number inside the range.
By their numbers in this assay, from the lowest: compound 1; then compounds 2, 3 and 4 (each within the scatter of the next).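

In this assay, putting a group on the amine nitrogen in the ring of compound 1 does not leave the number unchanged: pyridin-2-yl in place of hydrogen gives a 3.5-fold higher number from compound 1 to compound 4 (0.55 log units; beyond the scatter). This step has the same printed size as a 3.5-fold higher number from compound 1 to compound 2 (0.55 log units; beyond the scatter), so compounds 2 and 4, both lacking that amine hydrogen, stand at the same number. Nothing available explains this rise. On these data alone, whether a methyl or an acetyl group on that nitrogen would give a number close to that of compound 1 remains open.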